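The compounds below may be only part of what the source reports. "The series", "measured", "known", "first", "only" and "open" are said of these compounds alone.

Measured so far:
compound 1, `Cc1nc(-c2ccccc2)c(C(=O)N2CCN(c3c(C)cccc3C)CC2)o1` — 146 nM
compound 2, `COc1cccc(-c2nc(C)oc2C(=O)N2CCN(c3cccc(Cl)c3)CC2)c1` — "not active" (no number reported)

Going by the values given here, in a functional assay on HL-60 cells (Homo sapiens) for inhibition, read by MTT assay, with a stated time of 72 h (on this read-out lower numbers stand for stronger inhibition and higher numbers for weaker inhibition), compound 1 gives 146 nM, the only number in the set. Compound 2 is reported in this assay as "not active" (no number reported), with no number attached. Among the compounds with values here, compound 2 differs from compound 1 in more than one place, so no single step between them can be read; the two results show only that one member of the series has a measured value and the other does not.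

Compound 3, `Cc1nc(-c2ccccc2)c(C(=O)N2CCN(c3ccccc3F)CC2)o1`, is not yet measured in this assay. It departs from compound 1 by 2-fluorophenyl in place of 2,6-dimethylphenyl on an amine nitrogen in a ring.

Within the data shown here, no step between measured compounds is available, so the size of this change has no precedent. The only substituted-aryl variation on record, in compound 2, came with loss of a measurable value, though combined with a second change. A modest weakening beyond the scatter is expected for compound 3, as a 3.1-fold higher number from compound 1 to compound 3 (0.49 log units; beyond the scatter). In this assay compound 3 is estimated at 450 nM, in the range 120 nM to 3000 nM.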

Compound 3, half-maximal inhibitory concentration: 147 nM
Compound 3: the middle estimate sits 3.1-fold (0.49 log units) above what was measured; measured number inside the range.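

In this assay, going by these compounds alone, the swap of 2,6-dimethylphenyl for 2-fluorophenyl on the amine nitrogen in the ring gives a 1.0-fold higher number from compound 1 to compound 3 (0.00 log units; within the scatter) and so provides the first readable step. At this position, a measurable value in the same range does not depend on the 2,6-dimethylphenyl group, and an aryl group with 7 heavy atoms in place of 8 leaves the read-out within the scatter. No measurement offers an explanation for this lack of a shift.

Compound 2 differs from both compound 1 and compound 3 in more than one place, so those steps cannot be read, and its "not active" result cannot be assigned to either its chlorine-bearing aryl group or its methoxy-bearing phenyl group. Also open, from the compounds shown here alone, is how far this position tolerates other groups, such as unsubstituted phenyl, a pyridine, a benzyl group, or a phenyl ring carrying a carboxylic acid, since one step on one aryl pair defines no trend.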